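Ester variation on the shared core: a furan-2-yl prospect

The source may report more compounds than this note shows. Statements on the series, on what has been measured and on what is new or still open speak of the compounds shown alone.

Measured in a functional assay on DU-145 cells (Homo sapiens) for cytotoxicity, read by MTT assay; a lower number here means a stronger inhibitor, a higher number a weaker inhibitor:
- compound 1 `CCCCC(O)CC(=O)O[C@H](CC=C(C)C)C1=CC(=O)c2c(O)ccc(O)c2C1=O`: 45300 nM
- compound 2 `CC(C)=CC[C@@H](OC(=O)c1ccoc1)C1=CC(=O)c2c(O)ccc(O)c2C1=O`: > 100000 nM
- compound 3 `CCC(C)(O)CC(=O)O[C@H](CC=C(C)C)C1=CC(=O)c2c(O)ccc(O)c2C1=O`: 16000 nM

Compound 1 holds the highest of the two numbers shown; its nearest neighbour is compound 3, at a 2.8-fold lower number from compound 1 to compound 3 (0.45 log units; beyond the scatter). The value of compound 2 is a limit of this assay, not a number, (the limit of > 100000 nM in this assay, at which 1 of the 3 values shown sits).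

Compound 4 `CC(C)=CC[C@@H](OC(=O)c1ccco1)C1=CC(=O)c2c(O)ccc(O)c2C1=O` differs from compound 1 by furan-2-yl in place of 2-hydroxyhexyl on a carbonyl carbon. For the measured compounds named here, the one measured step that bears on this is the furan-3-yl case, an at least 2.2-fold higher number from compound 1 to compound 2 (0.34 log units; beyond the scatter), a move to a weaker inhibitor. A step of similar direction and size is expected for the furan-2-yl ester, with a fair chance that compound 4 again reaches only a limit. Compound 4 is expected near 100000 nM, between 40000 nM and 250000 nM. The expected step is a 2.2-fold higher number from compound 1 to compound 4 (0.34 log units; beyond the scatter).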

Compound 4, half-maximal inhibitory concentration: > 100000 nM
Compound 4: no number, only a limit; the forecaster's own chance of this, stated with the estimate: 60%; the middle value lies on the limit itself.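

Replacing the hydroxylated chains with furan-2-yl gives an at least 2.2-fold higher number from compound 1 to compound 4 (0.34 log units; beyond the scatter) and an at least 6.2-fold higher number from compound 3 to compound 4 (0.79 log units; beyond the scatter), so the loss seen with furan-3-yl is not confined to one furan attachment. Compound 4 gives a limit, not a number: the limit of > 100000 nM in this assay, at which 2 of the 4 values shown sit.

With both furan esters at that limit, the step between compound 2 and compound 4 cannot be read, and the two attachments cannot be ranked. On these data alone, whether a thiophen-2-yl or phenyl ester brings a readable number stays open, as does the effect of a longer hydroxylated chain on the carbonyl carbon.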